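The source may hold more compounds than are shown below. What is called first, only, known or untested is meant among the compounds shown, and "the series" means these compounds.

Measured compounds:
- compound 1 `O=C(O)c1ccc(OCCOc2ccc3cc2COC/C=C/COCc2cccc(c2)-c2ccnc(n2)N3)cc1`: > 100000 nM (a limit)
- compound 2 `O=C(O)CCCCCCCOc1ccc2cc1COC/C=C/COCc1cccc(c1)-c1ccnc(n1)N2`: 10000 nM

In an assay on Sf9 cells for inhibition of protein deacetylase HDAC6 (Homo sapiens), read by fluorescence, with a stated time of 2 h (a higher number here means a weaker inhibitor, a lower number a stronger inhibitor), compound 1 returns only a limit, > 100000 nM. In this assay, among the measured compounds shown here, compound 2 gives 10000 nM, the one number so far. The other entry, that of compound 1, sits at a limit, see (the limit of > 100000 nM in this assay, at which 1 of the 2 values shown sits). For the measured compounds named here, the single measured step, an at least 10-fold lower number from compound 1 to compound 2 (1.00 log units; beyond the scatter), replaces an aryl-linked acid with an alkyl acid chain and so does not speak to small changes in chain length.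

Compound 3 `O=C(O)CCCCCCOc1ccc2cc1COC/C=C/COCc1cccc(c1)-c1ccnc(n1)N2` differs from compound 2 by carboxy in place of carboxymethyl on a saturated chain carbon, six bonds along the chain from an oxygen on an aromatic ring. Going by the values given here, no measured step bears on the removal of one chain unit; the step from compound 1 to compound 2 is of a different kind. The expected change in this assay is therefore none beyond the scatter, estimated as a 1.2-fold higher number from compound 2 to compound 3 (0.08 log units; within the scatter). Compound 3 is estimated at 12000 nM, with a likely range from 4000 nM to 40000 nM.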

Compound 3, half-maximal inhibitory concentration: 2800 nM
Beside the measured number, compound 3's estimate is 4.3-fold (0.63 log units) above it; the whole stated range lies above it.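

In this assay, among the compounds shown here, removing one chain unit gives a 3.6-fold lower number from compound 2 to compound 3 (0.55 log units; beyond the scatter) at the site six bonds along the chain from an oxygen on an aromatic ring, the first reading on chain length alone, and it shows that this position responds to that small a change. Against the aryl-linked acid, the shorter alkyl acid chain gives an at least 35-fold lower number from compound 1 to compound 3 (1.55 log units; beyond the scatter) and widens the gap seen with the longer chain. That step starts from a limit, not a number, for compound 1: (the limit of > 100000 nM in this assay, at which 1 of the 3 values shown sits).

Going by these compounds, two alkyl acid chains fix a direction between compound 2 and compound 3 only, so whether a 3-carboxypropyl group would extend it remains open. Also open, on these data alone, is how a hydroxamic acid in place of the carboxylic acid would read in this assay on this chain.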